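Replacing the methyl of compound 2 with an amine side chain

The source may report more compounds than this note shows. Statements on the series, on what has been measured and on what is new or still open speak of the compounds shown alone.

Of the compounds shown here, two have been measured so far. In a physicochemical assay for lipophilicity (a lower number here means a more polar compound, a higher number a more lipophilic compound), compound 2 (`Cc1ccc2ncc(-c3cnc(Nc4ncccc4F)nc3)n2n1`) reads 2.5 and is the higher of the two, while compound 1 (`N[C@H]1CC[C@H](Nc2ccc3ncc(-c4cnc(Nc5ccccn5)nc4)n3n2)CC1`) reads 1.1 and lies lower by a gap beyond the scatter. These two differ in more than one place, so the gap is not a clean step.

Compound 3 (`Fc1cccnc1Nc1ncc(-c2cnc3ccc(NCCN4CCCC4)nn23)cn1`) has not yet been measured. Its difference from compound 2 is (2-(pyrrolidin-1-yl)ethyl)amino in place of methyl on an aromatic carbon and the new chain stands on an aromatic carbon, next to the ring nitrogen.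

Within the data shown here, no measured pair isolates this change. Among the measured compounds shown here, the only guide is compound 1 at 1.1 as it also carries a larger substituent joined through nitrogen. On that single comparison, a fall in this assay beyond the scatter is expected, with an estimated a number 1.20 log units lower from compound 2 to compound 3 (beyond the scatter) as the working figure. Compound 3 is estimated at 1.3 with an expected range from 0.7 to 1.9.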

Compound 3, distribution coefficient: 1.5
Compound 3: middle estimate off by 0.20 log units, on the low side, within the range that was stated.
By their numbers in this assay, from the lowest: compound 1; then compound 3; then compound 2.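

The step from methyl to (2-(pyrrolidin-1-yl)ethyl)amino gives the series its first reading of a change in one place: in this assay the result is a number 1.00 log units lower from compound 2 to compound 3 (beyond the scatter). At this position, on an aromatic carbon next to the ring nitrogen, the value therefore moves with the substituent when the rest of compound 2 stays fixed, so the gap seen earlier between two compounds differing in more than one place now has a clean counterpart. No measurement bears on which part of the new chain accounts for the step, and no cause can be assigned to it.

Among these compounds, the single step does not separate the contributions of the linking amine, the ethyl spacer and the terminal pyrrolidine, so a plain amino group, a methoxy group or a chain ending in morpholine at the same position would be needed to divide it. Among the compounds shown here, it also remains open whether a longer chain or a carboxylic acid on this carbon would extend the same trend, and how the fluorine on the outer ring acts on its own, since no measured pair isolates that atom.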